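The source may hold more compounds than are shown below. What is called first, only, known or untested is meant among the compounds shown, and "the series" means these compounds.

Compound 1, `CCS(=O)(=O)Nc1cc(-c2ccc3ncnc(Nc4ccc(F)cc4)c3c2)cnc1OC`, gives 1470 nM in a functional assay on SK-HEP1 cells (Homo sapiens) for cytotoxicity, read by sulforhodamine B assay, with a stated time of 72 h; on this read-out higher numbers stand for weaker inhibition and lower numbers for stronger inhibition. Compound 2, `CCS(=O)(=O)Nc1cc(-c2ccc3ncnc(Nc4ccc(OC)cc4)c3c2)cnc1OC`, gives 1610 nM in this assay. Compound 3, `CCS(=O)(=O)Nc1cc(-c2ccc3ncnc(Nc4ccc(C(=O)OC)c(OC)c4)c3c2)cnc1OC`, has not yet been measured in this assay.

Among the measured compounds shown here, on the two numbers in hand, compound 2 and compound 1 sit within the usual scatter of each other: the single measured step, a 1.1-fold higher number from compound 1 to compound 2 (0.04 log units; within the scatter), is too small to separate them. Compound 3 differs from compound 2 at the nitrogen on the aromatic ring: 3-methoxy-4-(methoxycarbonyl)phenyl in place of 4-methoxyphenyl on a nitrogen on an aromatic ring. For the measured compounds named here, the only measured step touches the same aromatic ring, where methoxy replaced fluoro, and it stayed within the scatter; it therefore gives little guidance for a change of this kind, which swaps the whole 4-methoxyphenyl for a 3-methoxy-4-(methoxycarbonyl)phenyl. Going by the values given here, with no measured step of comparable kind, compound 3 is expected to give a number near that of compound 2, with a wide range and a lean toward a higher number, so that the estimated step is a 1.6-fold higher number from compound 2 to compound 3 (0.19 log units; within the scatter). Compound 3 is estimated at 2500 nM in this assay, between 800 nM and 8000 nM.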

Compound 3, half-maximal inhibitory concentration: 830 nM
Compound 3: middle estimate off by 3.0-fold (0.48 log units), on the high side, and the stated range covers the measured number.
By their numbers in this assay, from the lowest: compounds 3, 1 and 2 (each within the scatter of the next).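

Among the compounds shown here, at this place, on a nitrogen on an aromatic ring, the earlier compounds showed only methoxy exchanged for fluoro, whereas compound 3 shows that a much larger group can be carried: 3-methoxy-4-(methoxycarbonyl)phenyl, with 12 heavy atoms in place of 8 and 3 hydrogen-bond acceptors in place of 1, gives a 1.9-fold lower number from compound 2 to compound 3 (0.29 log units; within the scatter) in this assay. Set against the 4-fluorophenyl, the same group gives a 1.8-fold lower number from compound 1 to compound 3 (0.25 log units; within the scatter), so neither step separates compound 3 from the earlier compounds, and in this cell read-out the three aryl groups cannot be told apart. Nothing available bears on why the added ester and methoxy groups leave the number within the scatter.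

The compounds shown leave open whether the 3-methoxy group or the 4-methoxycarbonyl group alone would give a number like that of compound 3, since the two enter together. They also leave open how a carboxylic acid or an amine in place of the methoxycarbonyl group would read in this assay, and whether any group at this place can move the number beyond the scatter.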